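The compounds below may be only part of what the source reports. "The series", "measured", "known", "first", "only" and "open" are said of these compounds alone.

Within the data shown here, in a functional assay (mast cells) for inhibition, with Rattus norvegicus as the target (on this read-out lower numbers stand for an effect already at smaller amounts and higher numbers for an effect only at larger amounts of compound), compound 1 (`CC1CC/C(=N\Nc2ccccc2F)c2ncc(C(=O)O)c(=O)n21`) gives 1200 nM and compound 2 (`CC1CC/C(=N\Nc2cccc(Cl)c2)c2ncc(C(=O)O)c(=O)n21`) gives 311000 nM as the higher of the two numbers so far, which puts compound 2 at the weaker end of this pair. Compound 3 (`CC1CC/C(=N\Nc2cccc(Br)c2)c2ncc(C(=O)O)c(=O)n21`) has not yet been measured. It differs from compound 2 by a single exchange, bromo in place of chloro on an aromatic carbon and, in short, bromo in place of chloro on an aromatic carbon, meta to a large group. Among the measured compounds shown here, the only measured step is a 260-fold higher number from compound 1 to compound 2 (2.41 log units; beyond the scatter) and it is large, but it replaced a differently substituted phenyl group with 3-chlorophenyl, so it changes more than the halogen alone. For the measured compounds named here, no measured pair changes only chloro to bromo at this place, and that large step therefore gives no direct size for the present exchange. A step beyond the scatter in this assay is not expected, in either direction. The estimated 1.2-fold lower number from compound 2 to compound 3 (0.09 log units; within the scatter) stays small. For compound 3 the expected value is 250000 nM within an estimated range from 50000 nM to 800000 nM on this thin evidence.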

Compound 3, half-maximal effective concentration: 6700 nM
Beside the measured number, compound 3's estimate is 37-fold (1.57 log units) above it; the measured number lies below the stated range.
By their numbers in this assay, from the lowest: compound 1; then compound 3; then compound 2.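

In this assay, the exchange of a single heavy atom, chloro to bromo, with no change in the count of hydrogen-bond donors, acceptors or charge, gives a large step (a 46-fold lower number from compound 2 to compound 3 (1.67 log units; beyond the scatter)). This shows that the read-out at this aromatic carbon, meta to a large group, depends strongly on which halogen sits there, which the earlier step could not show, since it also exchanged 2-fluorophenyl for 3-chlorophenyl (a 260-fold higher number from compound 1 to compound 2 (2.41 log units; beyond the scatter)). The 3-bromophenyl group still stands on the higher side of 2-fluorophenyl, but only by a modest step (a 5.6-fold higher number from compound 1 to compound 3 (0.75 log units; beyond the scatter)), so most of the large gap seen earlier does not carry over once bromo replaces chloro.

On these data alone, how an iodo or a methyl group on the same aromatic carbon would read in this assay remains open, and with only these two halogens at this place no trend across a series can be drawn. Nothing given here offers an explanation for why the two halogens differ so widely.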